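The source may hold more compounds than are shown below. What is called first, only, known or untested is meant among the compounds shown, and "the series" means these compounds.

Values in an ADME assay on HeLa cells (Homo sapiens) for cytotoxicity, read by LDH release, with a stated time of 24 h; a higher number here means a weaker inhibitor, a lower number a stronger inhibitor:
- compound 1 `COCCOCCOCc1ccc2c(Br)cc(Br)c(O)c2n1`: > 100000 nM, a limit
- compound 2 `COCCOCc1ccc2c(Br)cc(Br)c(O)c2n1`: > 100000 nM, a limit

Compound 2 therefore has no number, only the limit > 100000 nM. Going by the values given here, the series so far sits at one value: the limit of > 100000 nM in this assay, at which 2 of the 2 values shown sit.

Compound 3 `OCc1ccc2c(Br)cc(Br)c(O)c2n1` follows from compound 2 by hydrogen in place of 2-methoxyethyl on an oxygen on a saturated carbon. Among the compounds with values here, the only measured step bearing on this, a step that the two limits leave unreadable from compound 1 to compound 2, also shortens the chain, and its size cannot be read. The expected a number no higher from compound 2 to compound 3 (the limit leaves the size open) in this assay is therefore no step beyond the scatter, with no direction expected. Compound 3 is estimated at 100000 nM, with an expected range of 40000 nM to 200000 nM.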

Compound 3, half-maximal inhibitory concentration: > 100000 nM
Compound 3: only a limit was reported; the forecaster's own chance of this, stated with the estimate: 80%; the middle value sits exactly at the limit.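

Compound 3 adds no readable step: like compound 1 and compound 2, it has only a limit, so the steps among the three cannot be read. The compounds shown leave open what actual value any of them would give in this assay, and so whether the chain on the shared core matters there.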